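Sulfonyl aryl variation in a weakly inhibiting anilide series

This account rests on a few compounds, and the source may have more. Where it says the series, first, only, none or still open, it means among the compounds named here.

Compound 3 `CCN(CC)C(=O)CN(c1ccc(C)cc1)S(=O)(=O)c1ccccc1F` sits at a limit of the assay: in a functional assay on CHO cells for inhibition of Orexin/Hypocretin receptor type 1 (Homo sapiens), read by FLIPR and calcium flux (on this read-out lower numbers stand for stronger inhibition and higher numbers for weaker inhibition), compound 3 gives > 10000 nM. Compound 2 `CCN(CC)C(=O)CN(c1ccc(C)cc1)S(=O)(=O)c1cccc(Cl)c1` also reports only a limit, > 10000 nM in this assay. Compound 1 `CCN(CC)C(=O)CN(c1ccc(C)cc1)S(=O)(=O)c1ccc(OC)c(OC)c1` likewise stops at a limit, > 10000 nM. The step that the two limits leave unreadable from compound 2 to compound 3 therefore has no readable size, as the limit of > 10000 nM in this assay, at which 3 of the 3 values shown sit, shows. Compound 4 `CCN(CC)C(=O)CN(c1ccc(C)cc1)S(=O)(=O)c1ccc(OC)cc1` carries 4-methoxyphenyl in place of 2-fluorophenyl on a sulfonyl sulfur. For the measured compounds named here, no measured step with readable numbers bears on exchanging a 2-fluorophenyl for a 4-methoxyphenyl on the sulfonyl sulfur; every value shown ends at the same limit. Compound 4 is therefore expected to remain at that limit as well, with an estimated step that the limit leaves unreadable from compound 3 to compound 4 that cannot be separated from none beyond the scatter. The estimate for compound 4 in this assay is 20000 nM, between 8000 nM and 60000 nM.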

Compound 4, half-maximal inhibitory concentration: > 10000 nM
Compound 4 was reported as a limit (the forecaster's own chance of this, stated with the estimate: 85%); the middle value does not contradict the limit.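

In this assay, for the compounds shown here, compound 4 gives > 10000 nM as a limit, so no step from compound 1, compound 2 or compound 3 to compound 4 can be read: the limit of > 10000 nM in this assay, at which 4 of the 4 values shown sit. The compounds shown leave open whether any sulfonyl aryl group gives measurable inhibition.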